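The source may hold more compounds than are shown below. What is called first, only, known or untested is meant among the compounds shown, and "the series" means these compounds.

Working notes on the series. The shared core of compound 1 `COc1ccc2[nH]cc(C(=O)/C(C#N)=C/C=C(\Cl)c3ccc(OC)c(OC)c3)c2c1` carries a chain ending in a chlorine-bearing aryl group, and in a functional assay for inhibition, with a stated time of 5 min, tested at 1 mM (on this read-out higher numbers stand for more inhibition at the one concentration tested (going by the name of the read-out) and lower numbers for less inhibition), compound 1 gives 58.2%. Compound 2 `COc1ccc2[nH]cc(C(=O)/C(C#N)=C/C=C(\Cl)c3ccc(Br)cc3)c2c1` gives 54.5% in this assay, and compound 3 `N#C/C(=C\C=C(/Cl)c1ccc(Br)cc1)C(=O)c1c[nH]c2ccccc12` gives 65.5%. Among these three numbers compound 1 stands second highest; its nearest neighbour is compound 2, with a number 3.7 percentage points lower from compound 1 to compound 2 (within the scatter), and compound 3 lies furthest from it, yet that gap too is within the scatter, so no firm order among the three can be stated.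

Compound 4 `COc1ccc(/C(Cl)=C/C=C(\C#N)C(=O)c2c[nH]c3ccc(Br)cc23)cc1OC` is not yet measured. It differs from compound 1 thus: bromo in place of methoxy on an aromatic carbon. Among the measured compounds shown here, the one measured step at the same kind of place is a number 11 percentage points higher from compound 2 to compound 3 (beyond the scatter), hydrogen in place of methoxy on an aromatic carbon, a modest gain beyond the scatter. The step of a number 3.7 percentage points lower from compound 1 to compound 2 (within the scatter) concerned the aryl end of the chain and stayed within the scatter. For the measured compounds named here, a bromo entering where methoxy leaves has no direct precedent; loss of the methoxy is expected to carry a small gain, while the bromo itself is uncharted, so the expected step is a number 4.8 percentage points higher from compound 1 to compound 4 (within the scatter). Compound 4 is therefore estimated at 63%, with a range from 50% to 76%.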

Compound 4, a percentage reported as inhibition, at one concentration (the size of the read-out at that concentration, not a potency): 80.9%
For compound 4 the middle estimate is 17.9 percentage points below the measured one; measured number above the stated range.
By their numbers in this assay, from the lowest: compounds 2, 1 and 3 (each within the scatter of the next, the first and the last beyond it); then compound 4.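

Among the compounds shown here, at the aromatic carbon of the shared core that carries the methoxy in compound 1, this assay gives a number 22.7 percentage points higher from compound 1 to compound 4 (beyond the scatter), the first reading of a substituent entering there rather than the group simply leaving. For the compounds shown here, the only earlier reading at this place was a number 11 percentage points higher from compound 2 to compound 3 (beyond the scatter), with hydrogen in place of methoxy and a 4-bromophenyl chain end, so both pairs that lose the methoxy now move upward beyond the scatter, one with a 3,4-dimethoxyphenyl chain end and one with a 4-bromophenyl chain end, and neither pair goes against this. No measured evidence on the compounds bears on why the number moves at this position.

The pairs shown cannot separate the loss of the methoxy from the entry of the bromo, and whether fluoro, an amine or a carboxylic acid on the same aromatic carbon would follow the bromo remains open. Also open, as far as these compounds go, is whether the bromo would move the number in the same direction with a 4-bromophenyl chain end, and how any of this would look beyond a read-out taken at one concentration.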